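The compounds below may be only part of what the source reports. "The series", "measured", "known", "first", "only" and "open" are said of these compounds alone.

Going by the values given here, in an assay for inhibition of Fatty-acid amide hydrolase 1 (Rattus norvegicus) (on this read-out higher numbers stand for weaker inhibition and lower numbers for stronger inhibition), compound 2 `COc1ccc(CCCCCCC(=O)c2ncc(-c3ccccn3)o2)cc1` gives 6.2 nM, the lowest of the three numbers measured so far. Compound 1 `O=C(CCCCCCc1cccnc1)c1ncc(-c2ccccn2)o1` gives 32 nM, and compound 3 `CS(=O)(=O)c1ccc(CCCCCCC(=O)c2ncc(-c3ccccn3)o2)cc1` gives 19 nM. Compound 4 `CSc1cccc(CCCCCCC(=O)c2ncc(-c3ccccn3)o2)c1` differs from compound 2 by 3-(methylsulfanyl)phenyl in place of 4-methoxyphenyl on a saturated chain carbon, six bonds along the chain from a carbonyl carbon. Among the compounds with values here, two measured steps bear on this change: a 5.2-fold lower number from compound 1 to compound 2 (0.71 log units; beyond the scatter) shows that the ring on the saturated chain carbon, six bonds along the chain from a carbonyl carbon, moves the number, and a 3.1-fold higher number from compound 2 to compound 3 (0.49 log units; beyond the scatter) shows that exchanging the substituent on that ring shifts it modestly. Neither step matches the present exchange exactly, so for compound 4 a modest upward step of about a 1.8-fold higher number from compound 2 to compound 4 (0.25 log units; within the scatter) is expected. Compound 4 is thus estimated at 11 nM, within 3.5 nM to 35 nM.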

Compound 4, inhibition constant: 4.2 nM
Estimate against measurement, compound 4: 2.6-fold (0.42 log units) above, and the stated range covers the measured number.
By their numbers in this assay, from the lowest: compounds 4 and 2 (each within the scatter of the next); then compounds 3 and 1 (each within the scatter of the next).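

In this assay, replacing 4-methoxyphenyl with 3-(methylsulfanyl)phenyl on the saturated chain carbon gives a 1.5-fold lower number from compound 2 to compound 4 (0.17 log units; within the scatter) and so stays within the scatter, whereas the methylsulfonyl exchange that led to compound 3 lay beyond it. Against pyridin-3-yl at this place, 3-(methylsulfanyl)phenyl gives a 7.6-fold lower number from compound 1 to compound 4 (0.88 log units; beyond the scatter) and so also lies beyond the scatter. No measured evidence here accounts for either step. The compounds shown leave open whether the methylsulfanyl group or its place on the ring sets the number, as the two change together. They also leave open how a carboxylic acid or an amine on that ring, or a longer chain, would read.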